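The source may hold more compounds than are shown below. What is called first, only, known or untested is meant among the compounds shown, and "the series" means these compounds.

Two compounds have been measured in an assay on CHO cells for displacement of a labelled ligand from adenosine receptor A1 (Homo sapiens), read by scintillation counting, with a stated time of 90 min, tested at 1 uM, in the presence of a further agent that is not named here; a higher number here means more inhibition at the concentration tested (going by the name of the read-out), a lower number less inhibition:

Compound 1, `CCCn1c(=O)[nH]c2nc(-c3ccc(S(=O)(=O)N4CCN(c5ccc(F)cc5)CC4)cc3)[nH]c2c1=O`, gives 14%.
Compound 2, `CCCn1c(=O)[nH]c2nc(-c3ccc(S(=O)(=O)N4CCN(c5ccc(Cl)cc5F)CC4)cc3)[nH]c2c1=O`, gives 9%.

Within the data shown here, compound 2 holds the lower of the two numbers, but the only measured step, a number 5 percentage points lower from compound 1 to compound 2 (within the scatter), lies within the scatter, so the two compounds are not told apart by these data. Compound 3, `CCCn1c(=O)[nH]c2nc(-c3ccc(S(=O)(=O)N4CCN(c5ccc(Br)cc5)CC4)cc3)[nH]c2c1=O`, differs from compound 2 in one place: 4-bromophenyl in place of 4-chloro-2-fluorophenyl on an amine nitrogen in a ring. Among the measured compounds shown here, no measured step puts 4-bromophenyl on the ring nitrogen; the one step that bears on the question, a number 5 percentage points lower from compound 1 to compound 2 (within the scatter), exchanged one halogenated phenyl on that nitrogen for another and produced no change beyond the scatter. Compound 3 is therefore expected to stay close to compound 2, the expected step being a number 3 percentage points higher from compound 2 to compound 3 (within the scatter), with no direction beyond the scatter. In this assay compound 3 is estimated at 12%, with a range from 0% to 28%.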

Compound 3, a percentage reported as inhibition, at one concentration (the size of the read-out at that concentration, not a potency): 13%
Beside the measured number, compound 3's estimate is 1 percentage points below it, within the range that was stated.
By their numbers in this assay, from the lowest: compounds 2, 3 and 1 (each within the scatter of the next).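

With 4-bromophenyl in place of 4-chloro-2-fluorophenyl on the amine nitrogen in the ring, this assay gives a number 4 percentage points higher from compound 2 to compound 3 (within the scatter), and bromo in place of fluoro on an aromatic carbon gives a number 1 percentage points lower from compound 1 to compound 3 (within the scatter). The position now carries three halogenated phenyl groups that these data do not tell apart, and the exchange of one halogen for another at a single place on the phenyl also produces no change beyond the scatter. No measurement available here offers an explanation for this result.

The compounds shown all carry a halogenated phenyl at this position, so it remains open whether any other group there would move the inhibition beyond the scatter. A phenyl bearing a methoxy group or a carboxylic acid, or a benzyl group on that nitrogen, would test this.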